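The source may report more compounds than this note shows. Statements on the series, on what has been measured and on what is new or still open speak of the compounds shown alone.

The series shares one core and varies only the group on its aromatic ring. Compound 1 `C/N=C(/S)C1=CC(C)(C)Oc2ccc([N+](=O)[O-])cc21` carries a nitro group there, and in a functional assay (aorta) with Rattus norvegicus as the target (a higher number here means that more compound is needed for the effect, a lower number that less compound is needed), compound 1 gives 1.35 nM, the lowest of the three numbers measured. Compound 2 `C/N=C(/S)C1=CC(C)(C)Oc2ccc(S(C)(=O)=O)cc21` carries methylsulfonyl instead and in this assay compound 2 gives 457 nM; compound 3 `C/N=C(/S)C1=CC(C)(C)Oc2ccc(OC(C)=O)cc21` carries acetoxy and compound 3 gives 95.5 nM. Both replacements cost a great deal: a 340-fold higher number from compound 1 to compound 2 (2.53 log units; beyond the scatter) and a 71-fold higher number from compound 1 to compound 3 (1.85 log units; beyond the scatter), while between the two newcomers a 4.8-fold lower number from compound 2 to compound 3 (0.68 log units; beyond the scatter).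

Compound 4 `C/N=C(/S)C1=CC(C)(C)Oc2ccc(Cl)cc21` differs from compound 1 in one place: chloro in place of nitro on an aromatic carbon. Neither measured step tests chloro itself, but both swap out nitro on an aromatic carbon, and each raised the number by a large margin; the two newcomers sit only a modest step apart. Chloro enters as a single heavy atom with no hydrogen-bond acceptors, which neither measured replacement does, so the data give no direct precedent for it. A large rise in this assay is therefore expected, with the estimated step being a 37-fold higher number from compound 1 to compound 4 (1.57 log units; beyond the scatter). Compound 4 is expected to give about 50 nM in this assay, in an estimated range from 8 nM to 300 nM.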

Compound 4, half-maximal effective concentration: 37.2 nM
The estimate for compound 4 lay 1.3-fold (0.13 log units) above the measured number, within the range that was stated.
By their numbers in this assay, from the lowest: compound 1; then compound 4; then compound 3; then compound 2.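

In this assay the change to chloro still carries a large cost (a 28-fold higher number from compound 1 to compound 4 (1.44 log units; beyond the scatter)), so a third replacement of a quite different kind also falls well short of nitro at this position. Yet chloro gives the lowest number of the three replacements, with a modest gain over acetoxy (a 2.6-fold lower number from compound 3 to compound 4 (0.41 log units; beyond the scatter)) and a large gain over methylsulfonyl (a 12-fold lower number from compound 2 to compound 4 (1.09 log units; beyond the scatter)). Chloro has no hydrogen-bond acceptors and nitro has them, yet these two groups give the lowest numbers in the set, so the count of acceptors alone does not set the order among the compounds shown. Nothing measured here explains these differences.

As far as these compounds go, how a nitrile, a trifluoromethyl group or an amine on this aromatic carbon would compare remains open, as does whether any group can match the number given by nitro. From the compounds shown here alone, it is also open whether the same order of groups would hold with a change elsewhere on the shared core.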